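A Methyl Added to a Compound Held at the Limit

A few compounds are considered here, and "the series" means these few. Any claim that something is new, unique, unknown or untested is made for them only; others in the source may bear on it.

Three related compounds have so far been tested in an ADME assay on Huh-7 cells (Homo sapiens) for cytotoxicity, read by thymidine incorporation; a lower number here means that less compound is tolerated, a higher number that more compound is tolerated. In this assay compound 1 `COC(=O)N[C@H](C(=O)N1C[C@@H](C)C[C@H]1c1nc2cc(-c3cc4sc(-c5ccc6oc([C@@H]7C[C@H](C)CN7C(=O)[C@@H](NC(=O)OC)C(C)C)nc6c5)cc4s3)ccc2[nH]1)C(C)C` gives > 20000 nM, which is a limit of the assay and not a number. Compound 2 `COC(=O)N[C@H](C(=O)N1C[C@@H](C)C[C@H]1c1ncc(-c2cc3sc(-c4ccc5[nH]c([C@@H]6C[C@H](C)CN6C(=O)[C@@H](NC(=O)OC)C(C)C)nc5c4)cc3s2)[nH]1)C(C)C` gives > 20000 nM, again a limit. Compound 3 `COC(=O)N[C@H](C(=O)N1C[C@@H](C)C[C@H]1c1nc2cc(-c3cc4sc(-c5ccc6nc([C@@H]7C[C@H](C)CN7C(=O)[C@@H](NC(=O)OC)C(C)C)[nH]c6c5)cc4s3)ccc2[nH]1)C(C)C` gives > 20000 nM, also a limit. Compound 3 therefore has no exact value and cannot be ranked against the other two, and the whole set looks the same: the limit of > 20000 nM in this assay, at which 3 of the 3 values shown sit.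

Compound 4 `COC(=O)N[C@H](C(=O)N1C[C@@H](C)C[C@H]1c1nc2cc(-c3cc4sc(-c5ccc6nc([C@@H]7C[C@H](C)CN7C(=O)[C@@H](NC(=O)OC)C(C)C)n(C)c6c5)cc4s3)ccc2[nH]1)C(C)C` differs from compound 3 in one place: methyl in place of hydrogen on an aromatic nitrogen. It carries methyl in place of hydrogen on an aromatic nitrogen of a five-membered aromatic ring with 2 nitrogen, next to the ring atom that bears a large group.

For the measured compounds named here, no two tested compounds differ in just one place, so no measured step shows what this methyl does in this assay. The expectation rests on compound 3, whose result of > 20000 nM is a limit. The expected step of a number no higher from compound 3 to compound 4 (the limit leaves the size open) is no larger than the usual scatter, in neither direction. For compound 4 the estimated value is 20000 nM, with an expected range from 10000 nM to 40000 nM, and another limit is the likeliest report.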

Compound 4, half-maximal cytotoxic concentration: > 20000 nM
Compound 4: only a limit was reported; the forecaster's own chance of this, stated with the estimate: 75%; the middle value sits exactly at the limit.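

Compound 3 and compound 4 are both reported only as limits, and the step between them cannot be read. The whole set now looks the same: the limit of > 20000 nM in this assay, at which 4 of the 4 values shown sit. The compounds shown leave open whether methyl in place of hydrogen on an aromatic nitrogen changes the result in this assay at all, and in which direction.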